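Second Chloro on the Shared Purine-Like Core

The source may report more compounds than this note shows. Statements on the series, on what has been measured and on what is new or still open speak of the compounds shown alone.

Measured so far:
compound 1 `ClCc1cccc(Cn2cnc3ncnc(Cl)c32)c1`: 1540 nM
compound 2 `ClCc1cccc(Cn2cnc3c(Cl)ncnc32)c1`: 1440 nM

In a functional assay on UO-31 cells (Homo sapiens) for cytotoxicity, read by sulforhodamine B assay, with a stated time of 48 h (a lower number here means a stronger inhibitor of growth, a higher number a weaker inhibitor of growth), compound 1 gives 1540 nM. Compound 2, which carries its chloro on the other ring carbon of the same fused core, gives 1440 nM in this assay; the two numbers lie within the usual scatter of each other, so compound 1 cannot be set apart from compound 2 on these data.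

Compound 3 `ClCc1cccc(Cn2cnc3nc(Cl)nc(Cl)c32)c1` is not yet measured. It differs from compound 1 by chloro in place of hydrogen on an aromatic carbon. Going by the values given here, no pair of measured compounds shows the effect of adding a second chloro to this core, so the size of the step is not known from the data. The expectation is a step from compound 1 to compound 3 of a 1.3-fold lower number from compound 1 to compound 3 (0.11 log units; within the scatter), most likely none beyond the scatter. Compound 3 is estimated at 1200 nM, with a range from 400 nM to 4000 nM.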

Compound 3, concentration for 50% growth inhibition: 17400 nM
Estimate against measurement, compound 3: 15-fold (1.16 log units) below; the whole stated range lies below it.
By their numbers in this assay, from the lowest: compounds 2 and 1 (each within the scatter of the next); then compound 3.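

Chloro in place of hydrogen on the aromatic carbon between two ring nitrogen atoms gives an 11-fold higher number from compound 1 to compound 3 (1.05 log units; beyond the scatter) in this assay and so marks a much weaker inhibitor of growth. Compound 1 and compound 2 both carry hydrogen on this carbon and could not show this: here a change of a single heavy atom is enough to produce a large step on the shared core. Nothing measured here explains why this one chloro has so large an effect.

On these data alone, it remains open whether the loss belongs to chloro itself or would follow any group on this carbon, such as an amine, a methoxy group or a fluoro. Going by these compounds alone, it also remains open whether the same step would appear without the other chloro on the core, since only this one pair shows it.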